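Sulfonyl aryl variation in the cyclopentene sulfonamide acids

The source may hold more compounds than are shown below. What is called first, only, known or untested is meant among the compounds shown, and "the series" means these compounds.

Three analogues have been measured in a functional assay on a cell-free system (plasma) for inhibition of thromboxane A2 receptor (Homo sapiens), read by turbidimetry; on this read-out lower numbers stand for stronger inhibition and higher numbers for weaker inhibition. Compound 1 `O=C(O)CCC/C=C\CC1=CCC[C@@H]1NS(=O)(=O)c1ccccc1` gives 2300 nM. Compound 2 `O=C(O)COCCCCC1=CCC[C@@H]1NS(=O)(=O)c1ccc(Cl)c(Cl)c1` gives 1900 nM. Compound 3 `O=C(O)COCCCCC1=CCC[C@@H]1NS(=O)(=O)c1ccc(F)cc1F` gives 1800 nM. The three numbers lie within the scatter of one another, so no ranking among them is warranted; compound 3 sits in the same narrow band as compound 2 and compound 1.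

Compound 4 `O=C(O)COCCCCC1=CCC[C@@H]1NS(=O)(=O)c1ccccc1` is not yet measured. It differs from compound 3 in one place: phenyl in place of 2,4-difluorophenyl on a sulfonyl sulfur. Within the data shown here, the only measured step that bears on the sulfonyl aryl group is a 1.1-fold lower number from compound 2 to compound 3 (0.02 log units; within the scatter), which exchanged one substituted phenyl for another without a change beyond the scatter. Compound 1 also carries an unsubstituted phenyl on the sulfonyl sulfur, though with a different acid chain, and its value sits in the same band. Nothing here points to a shift in either direction on removing the two fluorines. The expected step is a 1.1-fold higher number from compound 3 to compound 4 (0.05 log units; within the scatter), none beyond the scatter. For compound 4 the estimate is 2000 nM, with a range from 1000 nM to 4000 nM.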

Compound 4, half-maximal inhibitory concentration: 2000 nM
The estimate for compound 4 equals the measured number at the digits printed; the measured number falls inside the stated range.
By their numbers in this assay, from the lowest: compounds 3, 2, 4 and 1 (each within the scatter of the next).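

In this assay, the sulfonyl sulfur tolerates an unsubstituted phenyl as well as either halogenated ring: a 1.1-fold higher number from compound 3 to compound 4 (0.05 log units; within the scatter), and a 1.1-fold higher number from compound 2 to compound 4 (0.02 log units; within the scatter). Among these compounds, compound 4 also allows the first comparison of the acid chains with phenyl held constant, and 3-(carboxymethoxy)propyl in place of 5-carboxypent-1-en-1-yl gives a 1.2-fold lower number from compound 1 to compound 4 (0.06 log units; within the scatter), so neither change separates these analogues. No measurement available here offers an explanation for these results.

Going by these compounds, whether an amine, a methoxy group or a second fused benzene ring on the sulfonyl aryl group would move the number beyond the scatter remains open. Also open, on these data alone, is whether a simple methyl group on the sulfonyl sulfur, with no aryl ring at all, would stay within this band.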